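Swapping an Imidazole for a Thienyl Sulfide: Expected Partition

The source may hold more compounds than are shown below. What is called first, only, known or untested is meant among the compounds shown, and "the series" means these compounds.

Compound 1 `CN1CCN(C[C@H]2CN(c3ccc(-n4cc(-c5ccccn5)cn4)c(F)c3)C(=O)O2)CC1`: 2.2
Compound 2 `O=C1O[C@@H](Cn2ccnc2)CN1c1ccc(-n2cc(-c3ccccn3)cn2)c(F)c1`: 1.73

Going by the values given here, in a physicochemical assay for lipophilicity, read by HPLC, measured as octanol-water partition (a lower number here means a more polar compound, a higher number a more lipophilic compound), compound 2 stands lowest of the two numbers, the only measured step being a number 0.47 log units lower from compound 1 to compound 2 (beyond the scatter). Compound 3 `O=C1O[C@@H](CSc2cccs2)CN1c1ccc(-n2cc(-c3ccccn3)cn2)c(F)c1` differs from compound 2 by (thiophen-2-yl)sulfanyl in place of 1H-imidazol-1-yl on a saturated chain carbon bound to a saturated ring carbon. Among the compounds with values here, that one measured step exchanges one ring with two nitrogens for another and never touches a sulfur-linked ring, so no measured step bears directly on this change. Judged from the structures alone, compound 3 is expected to lie far above compound 2 in this assay, an estimated step of a number 2.07 log units higher from compound 2 to compound 3 (beyond the scatter). Compound 3 is therefore expected to give 3.8, within 3.2 to 4.4.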

Compound 3, partition coefficient: 4.29
For compound 3 the middle estimate is 0.49 log units below the measured one; measured number inside the range.
By their numbers in this assay, from the lowest: compound 2; then compound 1; then compound 3.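

Compound 3 shows that this position, on a saturated chain carbon bound to a saturated ring carbon, allows far wider movement in this assay than the earlier pair suggested. The exchange of 1H-imidazol-1-yl for (thiophen-2-yl)sulfanyl gives a large rise (a number 2.56 log units higher from compound 2 to compound 3 (beyond the scatter)), and the exchange of 4-methylpiperazin-1-yl for the same group gives another (a number 2.09 log units higher from compound 1 to compound 3 (beyond the scatter)). Nothing measured here accounts for the size of these steps.

On these data alone, whether the rise belongs to the sulfur link or to the thiophene ring stays open. So does the reading of a phenyl ether or a carboxylic acid at this position.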